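This account rests on a few compounds, and the source may have more. Where it says the series, first, only, none or still open, it means among the compounds named here.

Measured compounds:

Compound 1, `Cc1ccc(-c2nc3ccccc3s2)cc1NC(=O)c1cc([N+](=O)[O-])ccc1Cl`: in an ADME assay on BJ cells (Homo sapiens) for cytotoxicity, with a stated time of 72 h (on this read-out lower numbers stand for an effect already at smaller amounts and higher numbers for an effect only at larger amounts of compound), compound 1 gives > 14000 nM, which is a limit of the assay and not a number.
Compound 2, `O=C(Nc1cc(-c2nc3ccccc3s2)ccc1F)c1cc([N+](=O)[O-])ccc1Cl`: in this assay compound 2 gives > 25000 nM, also a limit.
Compound 3, `Cc1ccc(-c2nc3ccccc3o2)cc1NC(=O)c1cc([N+](=O)[O-])ccc1Cl`: in this assay compound 3 gives > 14000 nM, again a limit.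

Compound 1 and compound 2 differ in one place: fluoro in place of methyl on an aromatic carbon. The step that the two limits leave unreadable from compound 1 to compound 2. Compound 1 and compound 3 differ in their cores: 1,3-benzoxazol-2-yl in place of 1,3-benzothiazol-2-yl on an aromatic carbon. The step that the two limits leave unreadable from compound 1 to compound 3. The reason no size can be read is that every value sits at a limit: the limit of > 14000 nM in this assay, at which 2 of the 3 values shown sit, and (the limit of > 25000 nM in this assay, at which 1 of the 3 values shown sits). None of the three compounds showed an effect on the cells within the tested range.

Compound 4, `O=C(Nc1cc(-c2nc3ccccc3o2)ccc1F)c1cc([N+](=O)[O-])ccc1Cl`, has not yet been measured. It differs from compound 3 by fluoro in place of methyl on an aromatic carbon. This is the same kind of change as that from compound 1 to compound 2, not the same change: there the place was para to a 1,3-benzothiazol-2-yl group, here it is para to a 1,3-benzoxazol-2-yl group. The step from compound 3 to compound 4 is expected to be a step that the limit leaves unreadable from compound 3 to compound 4, in line with the unreadable step between compound 1 and compound 2. Going by the values given here, compound 4 is expected to give about 20000 nM in this assay, between 10000 nM and 50000 nM, and most likely again only as a limit, because all three values so far sit at the limit of > 14000 nM in this assay, at which 2 of the 3 values shown sit, or (the limit of > 25000 nM in this assay, at which 1 of the 3 values shown sits).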

Compound 4, half-maximal effective concentration: > 25000 nM
Compound 4 ended at the assay's limit; the forecaster's own chance of this, stated with the estimate: 85%; middle value at least 1.2-fold (0.09 log units) from the limit.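

Compound 4 adds no readable step: its links to compound 3 and to compound 2 have no measurable size, because all these values are limits of the assay and not numbers: the limit of > 14000 nM in this assay, at which 2 of the 4 values shown sit. The second limit is: the limit of > 25000 nM in this assay, at which 2 of the 4 values shown sit. The compounds shown leave open whether fluoro in place of methyl, or 1,3-benzoxazol-2-yl in place of 1,3-benzothiazol-2-yl, changes the result in this assay.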